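A Side-Chain Swap on a Dopamine Transporter Ligand

This account rests on a few compounds, and the source may have more. Where it says the series, first, only, none or still open, it means among the compounds named here.

Of the compounds shown here, three have been measured in an assay on striatum with sodium-dependent dopamine transporter (Rattus norvegicus) as the target; on this read-out lower numbers stand for stronger inhibition and higher numbers for weaker inhibition. Compound 1 `CN1CC[C@H](c2ccc(Cl)cc2)C(C(=O)Oc2ccccc2)C1` gives 906 nM, compound 2 `C=CCOC[C@H]1CN(C)CC[C@@H]1c1ccc(Cl)cc1` gives 60 nM, and compound 3 `CN1CC[C@H](c2ccc(Cl)cc2)[C@@H](CC(=O)N(C)C)C1` gives 16 nM. Compound 3 thus stands lowest of the three, with compound 2 nearest and compound 1 furthest. Among the measured compounds shown here, the only measured step between two compounds differing in a single place is a 3.8-fold lower number from compound 2 to compound 3 (0.57 log units; beyond the scatter), in which allyloxy gave way to dimethylcarbamoyl on the saturated chain carbon bound to a saturated ring carbon.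

Compound 4 `CN1CC[C@H](c2ccc(Cl)cc2)[C@@H](CCCO)C1` is the next compound. Its difference from compound 3 is: 2-hydroxyethyl in place of dimethylcarbamoyl on a saturated chain carbon bound to a saturated ring carbon. The step from compound 2 to compound 3 is the one that bears on this change, as it altered the group at the same place and was modest, running toward lower numbers when dimethylcarbamoyl entered. Taking that group away again is expected to move the number back up by a modest amount. Compound 4 is therefore estimated at 45 nM, within 15 nM to 140 nM. The expected step is a 2.8-fold higher number from compound 3 to compound 4 (0.45 log units; beyond the scatter).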

Compound 4, inhibition constant: 16 nM
The estimate for compound 4 lay 2.8-fold (0.45 log units) above the measured number; the measured number falls inside the stated range.
By their numbers in this assay, from the lowest: compounds 3 and 4 (each within the scatter of the next); then compound 2; then compound 1.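

In this assay the swap of dimethylcarbamoyl for 2-hydroxyethyl gives no change at the digits printed from compound 3 to compound 4 (within the scatter) and so shows that the low number at this place does not depend on the amide: two groups that differ in heavy atoms and in hydrogen-bond donors read alike. Both also stand apart from allyloxy, since 2-hydroxyethyl gives a 3.8-fold lower number from compound 2 to compound 4 (0.57 log units; beyond the scatter) and dimethylcarbamoyl gives a 3.8-fold lower number from compound 2 to compound 3 (0.57 log units; beyond the scatter) on the same saturated chain carbon. No measurement at hand explains why these two groups read alike.

As far as these compounds go, whether the low number holds for quite different groups at this place stays open, for instance an amine, a carboxylic acid or a longer chain. From the compounds shown here alone, it is also open whether the hydroxyl of 2-hydroxyethyl matters at all, which a methoxy group in its place would test.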